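The source may hold more compounds than are shown below. What is called first, only, known or untested is meant among the compounds shown, and "the series" means these compounds.

Measured compounds in an ADME assay on cells (Mus musculus, strain BALB/c) for cytotoxicity, read by MTT assay, with a stated time of 24 h; a higher number here means that more compound is tolerated, a lower number that less compound is tolerated:
compound 1, `COc1cc(-c2nnc(SCc3ccccc3[N+](=O)[O-])o2)ccc1O`: 331000 nM
compound 2, `COc1cc(-c2nnc(SCc3c(F)cccc3F)o2)ccc1O`: 575000 nM

Compound 2 carries the higher of the two numbers in this assay, yet the gap to compound 1 is within the usual scatter, so the two cannot be ranked against each other. Among the measured compounds shown here, no pair differing in a single place has been measured, so no step size is established here.

Compound 3, `COc1cc(-c2nnc(SCc3ccccc3Br)o2)ccc1O`, has not yet been measured. It differs from compound 2 in one place: 2-bromophenyl in place of 2,6-difluorophenyl on a saturated chain carbon bound to a sulfur. The change leaves the shared core untouched and swaps one substituted phenyl ring for another at the same position.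

For the measured compounds named here, with only two measured compounds, both within scatter of each other and neither pair forming a single-change step, there is no basis for expecting a large movement. The step from compound 2 to compound 3 in this assay is expected to be a 1.3-fold lower number from compound 2 to compound 3 (0.11 log units; within the scatter), that is, none beyond the scatter. The estimate for compound 3 in this assay is 450000 nM, with a range from 200000 nM to 1000000 nM.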

Compound 3, half-maximal cytotoxic concentration: 363000 nM
Compound 3: the middle estimate sits 1.2-fold (0.09 log units) above what was measured; measured number inside the range.
By their numbers in this assay, from the lowest: compounds 1, 3 and 2 (each within the scatter of the next).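

In this assay, the place on a saturated chain carbon bound to a sulfur can now be read through single changes, which compounds 1 and 2 alone could not offer: 2-bromophenyl in place of 2,6-difluorophenyl gives a 1.6-fold lower number from compound 2 to compound 3 (0.20 log units; within the scatter), and bromo in place of nitro on an aromatic carbon gives a 1.1-fold higher number from compound 1 to compound 3 (0.04 log units; within the scatter). Both steps lie within the scatter, so neither exchange on the phenyl ring can be told apart from no change in this read-out, and among these three rings the place shows no measurable sensitivity. Nothing at hand offers an explanation for this outcome.

Going by these compounds, it remains open whether a group of another kind at this place, such as an amine, a carboxylic acid or a longer chain, would give a step beyond the scatter. Equally open, on these data alone, is whether a change in the shared core, such as an amine in place of its hydroxyl, would leave the number in this assay just as unmoved.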